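A Small Extension on a Cyclic Peptide Side Chain

The compounds below may be only part of what the source reports. "The series", "measured", "known", "first", "only" and "open" are said of these compounds alone.

Compound 1 `COc1ccc(C[C@H]2C(=O)N[C@@H](C)C(=O)N(C)[C@H]3Cc4ccc(cc4)Oc4cc(ccc4OC)C[C@@H](C(=O)N[C@H](C)C(=O)N[C@@H](CC=O)C(=O)N2C)N(C)C3=O)cc1`: 33.9 nM
Compound 2 `COc1ccc(C[C@H]2C(=O)N[C@@H](C)C(=O)N(C)[C@H]3Cc4ccc(cc4)Oc4cc(ccc4OC)C[C@@H](C(=O)N[C@H](C)C(=O)N(C/C=C/c4ccccc4)[C@@H](C)C(=O)N2C)N(C)C3=O)cc1`: 10.7 nM
Compound 3 `COc1ccc2cc1Oc1ccc(cc1)C[C@H]1C(=O)N(C)[C@@H](C2)C(=O)N[C@H](C)C(=O)N[C@@H](C)C(=O)N(C)[C@@H](Cc2ccc(C)cc2)C(=O)N[C@@H](C)C(=O)N1C`: 24 nM

All three values come from a functional assay on P388 cells (Mus musculus) for cytotoxicity; on this read-out higher numbers stand for weaker inhibition and lower numbers for stronger inhibition. The number for compound 3, 24 nM, is the middle one of the three. It lies within the usual scatter of the number for compound 1, while compound 2 has a lower number, and that gap lies beyond the scatter.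

The next compound to be tested is compound 4 `CCc1ccc(C[C@H]2C(=O)N[C@@H](C)C(=O)N(C)[C@H]3Cc4ccc(cc4)Oc4cc(ccc4OC)C[C@@H](C(=O)N[C@H](C)C(=O)N[C@@H](C)C(=O)N2C)N(C)C3=O)cc1`. It differs from compound 3 at one place: methyl in place of hydrogen on a saturated chain carbon bound to an aromatic carbon. This turns 4-methylphenyl into 4-ethylphenyl.

Going by the values given here, no measured pair here differs at only one place, so the data offer no direct guide to this change. The measured compounds differ from each other at more than one place, yet their numbers stay close, from compound 2 at 10.7 nM to compound 1 at 33.9 nM. The expected 1.3-fold higher number from compound 3 to compound 4 (0.10 log units; within the scatter) is therefore small and stays within the scatter. Compound 4 is expected to give about 30 nM, with an estimated range of 12 nM to 75 nM.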

Compound 4, half-maximal inhibitory concentration: 9.33 nM
Estimate against measurement, compound 4: 3.2-fold (0.51 log units) above, outside the stated range (below it).
By their numbers in this assay, from the lowest: compounds 4 and 2 (each within the scatter of the next); then compounds 3 and 1 (each within the scatter of the next).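

In this assay, changing 4-methylphenyl to 4-ethylphenyl gives a 2.6-fold lower number from compound 3 to compound 4 (0.41 log units; beyond the scatter) and so a stronger inhibition, a step that lies beyond the scatter. Going by these compounds alone, this is the first pair here that differs in one place only, and it shows that this position is sensitive: one added methyl on a saturated chain carbon bound to an aromatic carbon is enough to move the number by more than repeat measurements would. Nothing in the data explains why the number falls with this change.

On these data alone, whether a longer chain such as propyl or butyl lowers the number further or raises it again stays open, as does the outcome with an amine or a carboxylic acid at the end of this chain. As far as these compounds go, the step also rests on a single pair, so whether the same change acts alike on the other compounds is unknown.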